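A few compounds are considered here, and "the series" means these few. Any claim that something is new, unique, unknown or untested is made for them only; others in the source may bear on it.

Compound 1 `O=C(CCC(=O)OCCCCCCSc1ccc([N+](=O)[O-])c2nonc12)Nc1ccccc1F` is the reference point of the series. Going by the values given here, in an ADME assay on HUVEC cells (Homo sapiens) for cytotoxicity, read by MTT assay, with a stated time of 72 h (on this read-out lower numbers stand for stronger inhibition and higher numbers for weaker inhibition), compound 1 gives 840 nM, the lowest of the three numbers so far. Compound 3 `O=C(CCC(=O)OCCCCCCSc1ccc([N+](=O)[O-])c2nonc12)Nc1ccc(C(F)(F)F)cc1` gives 1390 nM in this assay, and the two numbers sit within the scatter of each other; compound 2 `O=C(CCC(=O)OCCCCCCSc1ccc([N+](=O)[O-])c2nonc12)Nc1ccccc1Cl` gives 2950 nM, and a 3.5-fold higher number from compound 1 to compound 2 (0.55 log units; beyond the scatter) lies beyond the scatter. The two steps that exchange the aryl group on the amide-type nitrogen are a 1.7-fold higher number from compound 1 to compound 3 (0.22 log units; within the scatter) and a 2.1-fold lower number from compound 2 to compound 3 (0.33 log units; beyond the scatter), both modest.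

Compound 4 `COc1ccc(NC(=O)CCC(=O)OCCCCCCSc2ccc([N+](=O)[O-])c3nonc23)cc1OC` is not yet measured. Its difference from compound 1 is 3,4-dimethoxyphenyl in place of 2-fluorophenyl on an amide-type nitrogen. Among the compounds with values here, no measured compound carries a 3,4-dimethoxyphenyl or any ring bearing hydrogen-bond acceptors, so the evidence is indirect: the aryl exchanges a 1.7-fold higher number from compound 1 to compound 3 (0.22 log units; within the scatter) and a 2.1-fold lower number from compound 2 to compound 3 (0.33 log units; beyond the scatter) stayed small, while the chloro-for-fluoro step a 3.5-fold higher number from compound 1 to compound 2 (0.55 log units; beyond the scatter) shows that a change on this ring can move the number somewhat. A small step toward a higher number, inside a wide band, is therefore expected. For compound 4 the expected outcome in this assay is 1300 nM, between 500 nM and 3500 nM, which means an estimated step of a 1.5-fold higher number from compound 1 to compound 4 (0.19 log units; within the scatter).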

Compound 4, half-maximal inhibitory concentration: 870 nM
Compound 4: the middle estimate sits 1.5-fold (0.17 log units) above what was measured; the measured number falls inside the stated range.
By their numbers in this assay, from the lowest: compounds 1, 4 and 3 (each within the scatter of the next); then compound 2.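

In this assay, going by these compounds alone, the 3,4-dimethoxyphenyl group is the first aryl group to carry hydrogen-bond acceptors, and it brings more heavy atoms to the amide-type nitrogen than the 2-fluorophenyl group it replaces. Even so, a 1.0-fold higher number from compound 1 to compound 4 (0.02 log units; within the scatter) and a 1.6-fold lower number from compound 3 to compound 4 (0.20 log units; within the scatter) both lie within the scatter, so compound 4 cannot be told apart from compound 1 or compound 3 on this read-out, and this change on the ring does not by itself shift the number. Within the data shown here, with a 3.4-fold lower number from compound 2 to compound 4 (0.53 log units; beyond the scatter) as the remaining new step, compound 2 is now the only compound whose steps to all the others lie beyond the scatter, though nothing measured on these compounds bears on why the 2-chlorophenyl group stands apart.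

The compounds shown do not settle whether that separation belongs to the chlorine itself or to where it sits, which a 4-chlorophenyl group on the same nitrogen would address. As far as these compounds go, an amine or a carboxylic acid on the ring, a cyclohexyl group in place of the aryl ring, and a longer chain in the linker all remain open.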